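A few compounds are considered here, and "the series" means these few. Any claim that something is new, unique, unknown or untested is made for them only; others in the source may bear on it.

Measured in a functional assay on DU-145 cells (Homo sapiens) for cytotoxicity, read by MTT assay, with a stated time of 72 h; a lower number here means that less compound is needed, a higher number that more compound is needed for the effect:
- compound 1 `COc1ccc(Nc2cc(C3CCCCC3)oc(=O)c2)cc1`: 8.61 uM
- compound 2 `CCCCCc1cc(Nc2ccc(OC)cc2)cc(=O)o1`: 5.94 uM
- compound 3 `COc1ccccc1Nc1cc(-c2ccccc2)oc(=O)c1`: 0.37 uM

Among the compounds with values here, compound 2 gives 5.94 uM, which cannot be separated from the value of compound 1, as the one measured step shows: a 1.4-fold lower number from compound 1 to compound 2 (0.16 log units; within the scatter). Compound 3 gives 0.37 uM, a value that both of these clearly exceed.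

The next compound is compound 4 `COc1ccc(Nc2cc(-c3ccccc3)oc(=O)c2)cc1`, with this change: phenyl in place of pentyl on an aromatic carbon. Phenyl thus takes the place of pentyl, next to the ring oxygen. The measured step from cyclohexyl to pentyl bears on this only loosely, since neither group is phenyl and that step stayed within the scatter. The better guide is compound 3, which also carries phenyl and gives 0.37 uM. However, it differs from compound 4 in the placing of its methoxy group, so only part of its gap to compound 2 is expected to carry over.

A lower number is therefore expected, with the estimated step being a 4.0-fold lower number from compound 2 to compound 4 (0.60 log units; beyond the scatter). For compound 4 the estimated value is 1.5 uM, with an expected range from 0.4 uM to 6 uM.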

Compound 4, concentration for half-maximal effect: 0.12 uM
Estimate against measurement, compound 4: 13-fold (1.10 log units) above, and the stated range ends above it.
By their numbers in this assay, from the lowest: compound 4; then compound 3; then compounds 2 and 1 (each within the scatter of the next).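

Within the data shown here, until now the only step at this position, from cyclohexyl to pentyl, lay within the scatter, which gave no sign that the group there mattered. Phenyl in place of pentyl gives a 50-fold lower number from compound 2 to compound 4 (1.69 log units; beyond the scatter) and phenyl in place of cyclohexyl gives a 72-fold lower number from compound 1 to compound 4 (1.86 log units; beyond the scatter), so in this assay the group next to the ring oxygen has a large bearing on the number, and a ring alone is not enough, since compound 1 also carries one. Nothing measured here gives a reason for this difference.

From the compounds shown here alone, what a pyridine ring, a chlorophenyl group or a short chain such as methyl would give at this position remains open. Going by these compounds, it also remains open whether the gain from phenyl holds when the aniline ring carries something other than methoxy.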